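The source may report more compounds than this note shows. Statements on the series, on what has been measured and on what is new or still open speak of the compounds shown alone.

Measured so far in a functional assay on KB cells (Homo sapiens) for inhibition, read by MTT assay, with a stated time of 24 h, tested at 0.1 ug/mL; a lower number here means less inhibition of growth, a higher number more inhibition of growth at the concentration tested:
Compound 1 `O=C(CCCCC1CCSS1)NO` gives 7.92%
Compound 2 `O=C(CCCCC1CCSS1)Nc1ccccc1Cl` gives 5.11%
Compound 3 `O=C(CCCCC(S)CCS)Nc1ccc(Cl)cc1` gives 9.11%

These three numbers lie within the usual scatter of repeated measurements of one another, so they cannot be ranked, and compound 3 at 9.11% stands level with the other two. Compound 4 `COc1ccc(NC(=O)CCCCC(S)CCS)cc1` is still unmeasured. It keeps the structure of compound 3 except for one substituent: methoxy in place of chloro on an aromatic carbon. In words, methoxy takes the place of chloro on an aromatic carbon, para to a large group.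

Within the data shown here, no two measured compounds differ in only one place, so nothing here shows directly what such a swap does. Even so, compound 1 at 7.92% and compound 2 at 5.11% differ from compound 3 in more than one place and remain within the scatter of it. No step beyond the scatter is therefore expected, in either direction. The estimated change is a number 0.1 percentage points lower from compound 3 to compound 4 (within the scatter) in this assay overall. For compound 4 the expected value is 9%, with an estimated range from 2% to 20% as its span.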

Compound 4, percent growth inhibition at one concentration: "not active" (no number reported)
No number was reported for compound 4, and the estimate cannot be compared.
By their numbers in this assay, from the lowest: compounds 2, 1 and 3 (each within the scatter of the next).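

In this assay, among these compounds, compound 4 is reported only as "not active", without a number, so no step from compound 3 can be read. The compounds shown leave open what placing methoxy instead of chloro does to growth inhibition. No measurement here offers an explanation for this result.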